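Methyl to hydrogen on the core of compound 2

This account rests on a few compounds, and the source may have more. Where it says the series, first, only, none or still open, it means among the compounds named here.

Measured in an ADME assay on the whole organism (Rattus norvegicus, strain Fischer 344) for pharmacokinetics, with a stated time of 8 h, at a dose of 3 mg/kg by the oral route; a higher number here means more compound in the circulation at the dose given, a lower number less compound in the circulation:
- compound 1 `NC(=O)c1sc2nccc(N3CCC[C@H](COCC(=O)N4CCOCC4)C3)c2c1N`: 756 ng.h/mL
- compound 2 `CCOCCOC[C@H]1CCCN(c2cc(C)nc3sc(C(N)=O)c(N)c23)C1`: 1350 ng.h/mL

In this assay, going by the values given here, compound 2 gives 1350 ng.h/mL and its only neighbour, compound 1, gives 756 ng.h/mL. These two values lie within the usual scatter of each other, so they set a common level and no ranking.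

The next structure is compound 3 `CCOCCOC[C@H]1CCCN(c2ccnc3sc(C(N)=O)c(N)c23)C1`, which has hydrogen in place of methyl on an aromatic carbon. That carbon sits next to the ring nitrogen of the six-membered aromatic ring.

Among the compounds with values here, no measured pair isolates this change, so the data give no direct size for it. Within the data shown here, the only guide is the level shared by compound 1 at 756 ng.h/mL and compound 2 at 1350 ng.h/mL. A small drop or none at all is expected, with no step beyond the scatter.

The estimate means a step of a 1.4-fold lower number from compound 2 to compound 3 (0.13 log units; within the scatter), which is expected to stay within the scatter.

For compound 3 the expected value is 1000 ng.h/mL, with an estimated range of 450 ng.h/mL to 2200 ng.h/mL.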

Compound 3, area under the concentration-time curve in the Rattus norvegicus assay: 2000 ng.h/mL
Compound 3: the middle estimate sits 2.0-fold (0.30 log units) below what was measured; the measured number falls inside the stated range.
By their numbers in the Rattus norvegicus assay, from the lowest: compounds 1, 2 and 3 (each within the scatter of the next, the first and the last beyond it).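

In the Rattus norvegicus assay, compound 2 gives 1350 ng.h/mL and compound 3 gives 2000 ng.h/mL with hydrogen in place of methyl on the aromatic carbon next to the ring nitrogen, a change that gives a 1.5-fold higher number from compound 2 to compound 3 (0.17 log units; within the scatter), so this methyl is not required to hold the level of circulating compound seen in this pair. In a physicochemical assay for solubility, at pH 6.8 (a lower number here means a less soluble compound, a higher number a more soluble compound), compound 2 gives 560 ug/mL and compound 3 gives 500 ug/mL and the same change gives a 1.1-fold lower number from compound 2 to compound 3 (0.05 log units; within the scatter), so neither read-out separates the two compounds. Going by these compounds alone, the side chain now gives the only step beyond the scatter: in the Rattus norvegicus assay, ethoxymethyl in place of (morpholin-4-yl)carbonyl gives a 2.6-fold higher number from compound 1 to compound 3 (0.42 log units; beyond the scatter), a modest step that places the larger readable difference at this part of the series rather than at the aromatic carbon.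

On these data alone, it remains open whether a group such as ethyl, methoxy or an amine on the same aromatic carbon would keep this level, and whether the side-chain step would keep its size on the methyl-bearing core. The data at hand give no explanation for either step.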